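Amide side-chain swap in a piperazine melanocortin series

The source may report more compounds than this note shows. Statements on the series, on what has been measured and on what is new or still open speak of the compounds shown alone.

Measured compounds:
Compound 1 `NC(COCc1ccccc1)c1cc(F)ccc1N1CCN(C(=O)CCc2ccc(Cl)cc2Cl)CC1`: 1000 nM in an assay on HEK293 cells for displacement of a labelled ligand from Melanocortin receptor 4 (Homo sapiens); a higher number here means a weaker inhibitor, a lower number a stronger inhibitor
Compound 2 `COc1ccc(CCC(=O)N2CCN(c3ccc(C(F)(F)F)cc3[C@@H](N)CC(C)C)CC2)cc1`: 350 nM in this assay

Of the two numbers, compound 2 holds the lower one; compound 1 stands at a higher value, and that gap lies beyond the scatter. Compound 3 `CC(C)C[C@H](N)c1cc(C(F)(F)F)ccc1N1CCN(C(=O)CCc2cn(C)c3ccccc23)CC1` is not yet measured. It differs from compound 2 in one place: 1-methyl-1H-indol-3-yl in place of 4-methoxyphenyl on a saturated chain carbon, two bonds along the chain from a carbonyl carbon. Within the data shown here, no measured pair shows this change, so its size is unknown from the data. The expected step is a 1.2-fold lower number from compound 2 to compound 3 (0.07 log units; within the scatter), meaning nothing beyond the scatter in either direction. Compound 3 is therefore estimated at 300 nM, with a range from 70 nM to 1300 nM.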

Compound 3, inhibition constant: 3000 nM
Beside the measured number, compound 3's estimate is 10-fold (1.00 log units) below it; the measured number lies above the stated range.
By their numbers in this assay, from the lowest: compound 2; then compound 1; then compound 3.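

The group on the saturated chain carbon, two bonds along the chain from a carbonyl carbon, is not a silent position: in this assay 1-methyl-1H-indol-3-yl in place of 4-methoxyphenyl gives an 8.6-fold higher number from compound 2 to compound 3 (0.93 log units; beyond the scatter). Among these compounds, this is the first single-place step, and it goes toward weaker inhibition. Nothing measured here accounts for the step.

Still open, from the compounds shown here alone, is whether the loss follows the indole as a whole or its 1-methyl group, which an unsubstituted 1H-indol-3-yl would separate. A plain phenyl or 4-hydroxyphenyl at this position would show whether the methoxy group matters to compound 2.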